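The source may hold more compounds than are shown below. What is called first, only, known or untested is meant among the compounds shown, and "the series" means these compounds.

In a functional assay on HeLa cells (Homo sapiens) for inhibition, with a stated time of 72 h (a higher number here means that more compound is needed for the effect, a lower number that less compound is needed), three compounds have been measured so far. Compound 1 `COc1cc(CNCc2ccncc2)ccc1OCc1ccccc1F` gives 5100 nM, compound 2 `COc1cc(CNCc2ccncc2)ccc1OCc1ccc(C)cc1` gives 5000 nM, and compound 3 `COc1cc(CNCCCN(C)C)ccc1OCc1ccc(Cl)nc1` gives 5000 nM, so compound 3 stands level with the other two, within the scatter. Compound 4 `COc1cc(CNCc2ccncc2)ccc1OCc1ccc(Cl)nc1` differs from compound 3 in one place: pyridin-4-yl in place of 2-(dimethylamino)ethyl on a saturated chain carbon bound to an amine nitrogen. In words, this is pyridin-4-yl in place of 2-(dimethylamino)ethyl on a saturated chain carbon bound to an amine nitrogen. For the measured compounds named here, the only measured single-place step, a 1.0-fold lower number from compound 1 to compound 2 (0.01 log units; within the scatter), concerns a saturated chain carbon bound to an oxygen on an aromatic ring, not the place that changes here. Compound 1 and compound 2 already carry the ((pyridin-4-yl)methyl)amino group that compound 4 gains, and they read no differently from compound 3 at 5000 nM. The exact swap has not been measured, but no step beyond the scatter is expected in this assay. The expected step is no change at the digits printed from compound 3 to compound 4 (within the scatter). For compound 4 the estimated value is 5000 nM, with an expected range of 2500 nM to 10000 nM.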

Compound 4, half-maximal effective concentration: 400 nM
For compound 4 the middle estimate is 13-fold (1.10 log units) above the measured one; the measured number lies below the stated range.
By their numbers in this assay, from the lowest: compound 4; then compounds 2, 3 and 1 (each within the scatter of the next).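

In this assay, for the compounds shown here, the place on a saturated chain carbon bound to an amine nitrogen turns out to matter: with 6-chloropyridin-3-yl kept, pyridin-4-yl in place of 2-(dimethylamino)ethyl gives a 13-fold lower number from compound 3 to compound 4 (1.10 log units; beyond the scatter) and no earlier compound showed this. The place on a saturated chain carbon bound to an oxygen on an aromatic ring, flat between 2-fluorophenyl and 4-methylphenyl, also responds: 6-chloropyridin-3-yl gives a 13-fold lower number from compound 2 to compound 4 (1.10 log units; beyond the scatter) in place of 4-methylphenyl and a 13-fold lower number from compound 1 to compound 4 (1.11 log units; beyond the scatter) in place of 2-fluorophenyl. Among these compounds, the lower number appears only where the ((pyridin-4-yl)methyl)amino and 6-chloropyridin-3-yl groups stand together.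

On these data alone, whether a benzyl group on the amine, or a pyridin-3-yl group without the chlorine, would keep that lower number remains open. Nothing shown gives a reason for these steps.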